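Acetylpyrrolidine amide after three close amine amides

The compounds below may be only part of what the source reports. "The series", "measured", "known", "first", "only" and "open" are said of these compounds alone.

In a physicochemical assay for solubility, read by spectrophotometry, measured as kinetic solubility, at pH 8, tested at 500 uM (a higher number here means a more soluble compound, a lower number a less soluble compound), compound 1 `Cn1ccc2ccc(-c3cc(Nc4cnccc4C(=O)NCC4COCCN4)cc4nccnc34)cc21` gives 239 ug/mL and compound 2 `CN1CC(NC(=O)c2ccncc2Nc2cc(-c3ccc4ccn(C)c4c3)c3nccnc3c2)C1` gives 170 ug/mL on the same scale. Compound 3 `CN1CCC(CNC(=O)c2ccncc2Nc2cc(-c3ccc4ccn(C)c4c3)c3nccnc3c2)C1` stands at 246 ug/mL and lies within the scatter of both others.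

The next structure is compound 4 `CC(=O)N1CCC(NC(=O)c2ccncc2Nc2cc(-c3ccc4ccn(C)c4c3)c3nccnc3c2)C1` with the change 1-acetylpyrrolidin-3-yl in place of (1-methylpyrrolidin-3-yl)methyl on an amide-type nitrogen at the same site. In words, 1-acetylpyrrolidin-3-yl comes in place of (1-methylpyrrolidin-3-yl)methyl on an amide-type nitrogen.

Among the compounds with values here, three measured steps bear on this change. They are a 1.4-fold lower number from compound 1 to compound 2 (0.15 log units; within the scatter) and a 1.0-fold higher number from compound 1 to compound 3 (0.01 log units; within the scatter) and a 1.4-fold higher number from compound 2 to compound 3 (0.16 log units; within the scatter) and none leaves the scatter. The third is the closest, as it also swaps one methylated ring amine group for another on the amide-type nitrogen. None of the three puts an acetyl group on a ring nitrogen, so the data hold no direct measure of that part of the change. The close agreement covers only compound 1, compound 2 and compound 3.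

With that gap, a step to a lower number, larger than any measured so far, is expected but uncertain. The estimated step is a 2.5-fold lower number from compound 3 to compound 4 (0.39 log units; beyond the scatter) on present evidence. For compound 4 the expected value is 100 ug/mL with an estimated range from 25 ug/mL to 240 ug/mL until measured.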

Compound 4, solubility: 253 ug/mL
For compound 4 the middle estimate is 2.5-fold (0.40 log units) below the measured one; measured number outside the range, above it.
By their numbers in this assay, from the lowest: compounds 2, 1, 3 and 4 (each within the scatter of the next).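

Within the data shown here, on the amide-type nitrogen, 1-acetylpyrrolidin-3-yl gives the first reading in this set for an acetyl group on the ring nitrogen, and in this assay the exchange for (1-methylpyrrolidin-3-yl)methyl stays within the scatter (a 1.0-fold higher number from compound 3 to compound 4 (0.01 log units; within the scatter)). The comparisons with the other two groups at this site also stay within the scatter (a 1.5-fold higher number from compound 2 to compound 4 (0.17 log units; within the scatter); a 1.1-fold higher number from compound 1 to compound 4 (0.02 log units; within the scatter)), so the acetyl amide joins the methylated ring amines and the morpholine in one band, and none of the four groups at this site is separated from another. No measurement in hand offers an explanation for this flat result.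

The step from compound 3 to compound 4 both removes the methylene link and replaces methyl with acetyl on the ring nitrogen, so a group such as (1-acetylpyrrolidin-3-yl)methyl would be needed to read those two parts apart. On these data alone, whether any group on this nitrogen can leave the band also remains open, and a carboxylic acid or a longer chain carrying a primary amine would put that to the test.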